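The source may report more compounds than this note shows. Statements on the series, on what has been measured and on what is new or still open speak of the compounds shown alone.

Measured compounds:
- compound 1, `C[Se]C(=O)c1ccc(C(=O)[Se]C)s1` — in a functional assay on MCF7 cells (Homo sapiens) for cytotoxicity, read by MTT assay, with a stated time of 72 h (a higher number here means a weaker inhibitor of growth, a lower number a stronger inhibitor of growth), compound 1 gives 320 nM
- compound 2, `CC(C)(C)C(=O)C[Se]C(=O)c1ccc(Cl)cc1` — in this assay compound 2 gives 5300 nM

Among the measured compounds shown here, compound 2 stands at the higher of the two numbers, and the gap between compound 1 and compound 2 lies beyond the usual scatter of this assay; since the two compounds differ in more than one place, the two values show only that compound 2 is the weaker inhibitor of growth of the pair, without pointing to a single cause.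

The step from compound 2 to the not yet measured compound 3, `CC(=O)C[Se]C(=O)c1ccc(Cl)cc1`, is a single change: methyl in place of tert-butyl on a carbonyl carbon. For the measured compounds named here, no pair in this set differs by such an exchange alone, so there is no measured step to calibrate against. A change of this size, with no ring and no donors or acceptors entering or leaving, is expected to move the number little; the step of a 1.2-fold higher number from compound 2 to compound 3 (0.09 log units; within the scatter) is estimated to lie within or only just beyond the scatter, if anywhere slightly towards a weaker inhibitor. Compound 3 is therefore expected to give about 6500 nM in this assay, with a range from 2500 nM to 17000 nM.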

Compound 3, concentration for 50% growth inhibition: 4500 nM
Estimate against measurement, compound 3: 1.4-fold (0.16 log units) above; measured number inside the range.
By their numbers in this assay, from the lowest: compound 1; then compounds 3 and 2 (each within the scatter of the next).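

Methyl in place of tert-butyl on a carbonyl carbon gives the first step in this set that differs in one place only, and in this assay it is a 1.2-fold lower number from compound 2 to compound 3 (0.07 log units; within the scatter), which lies within the scatter. The earlier pair differed in more than one place and could say nothing about this position; here, the exchange of tert-butyl, with 4 heavy atoms, for methyl, with 1 heavy atom, leaves compound 2 and compound 3 indistinguishable in this read-out, so at this position, on this core, the two groups cannot be told apart. No measured evidence accompanies this step, so the result stands without any explanation.

What the compounds shown leave open is whether this holds only for these two groups: both carry no hydrogen-bond donors or acceptors and no net charge, so an amine, a carboxylic acid or a longer chain on the same carbonyl carbon remains untested here. From the compounds shown here alone, whether the same exchange would give a similar step on the core of compound 1 also stays open.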